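The compounds below may be only part of what the source reports. "The series", "measured", "known", "first", "only" and "open" are said of these compounds alone.

Compound 1 `O=C1/C(=C/c2cccnc2)CN(S(=O)(=O)c2ccc(F)cc2)C/C1=C\c1ccccc1C(F)(F)F` and compound 3 `O=C1/C(=C/c2ccncc2)CN(S(=O)(=O)c2ccc(F)cc2)C/C1=C\c1ccccc1C(F)(F)F` share most of their structure and differ in the way told by pyridin-4-yl in place of pyridin-3-yl on a double-bonded chain carbon bound to a double-bonded ring carbon. In a functional assay on QGY-7703 cells (Homo sapiens) for cytotoxicity, read by MTT assay, with a stated time of 24 h (a higher number here means a weaker inhibitor, a lower number a stronger inhibitor), compound 1 gives 6030 nM, and compound 3 gives 7700 nM; the step is a 1.3-fold higher number from compound 1 to compound 3 (0.11 log units; within the scatter). Compound 2 `O=C1/C(=C/c2cccnc2)CN(S(=O)(=O)c2ccc(Cl)cc2)C/C1=C\c1ccccc1C(F)(F)F` is built from compound 1 by chloro in place of fluoro on an aromatic carbon, and in this assay compound 2 gives 3440 nM, which is a 1.8-fold lower number from compound 1 to compound 2 (0.24 log units; within the scatter). Compound 4 `O=C1/C(=C/c2ccncc2)CN(S(=O)(=O)c2ccc(Cl)cc2)C/C1=C\c1ccccc1C(F)(F)F` has not yet been measured in this assay; it stands to compound 3 as compound 2 stands to compound 1, the change being (chloro in place of fluoro on an aromatic carbon), made at a place described in the same words both times, so the two changes are the same change on two different cores. For the measured compounds named here, the step it made once is the only guide to the step it will make again. For compound 4 the expected step in this assay is a 1.8-fold lower number from compound 3 to compound 4 (0.24 log units; within the scatter), resting on a 1.8-fold lower number from compound 1 to compound 2 (0.24 log units; within the scatter) and on the number of compound 3, 7700 nM. On that basis compound 4 is estimated at 4400 nM in this assay, with a range from 2500 nM to 8000 nM.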

Compound 4, half-maximal inhibitory concentration: 12700 nM
Estimate against measurement, compound 4: 2.9-fold (0.46 log units) below; the whole stated range lies below it.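

In this assay the new step is a 1.6-fold higher number from compound 3 to compound 4 (0.22 log units; within the scatter), which is within the scatter taken alone, as is the earlier step, so neither step gives a direction by itself, yet chloro in place of fluoro does not carry over unchanged from one core to the other: the same change on two cores in this assay, a 1.8-fold lower number (0.24 log units; within the scatter) from compound 1 to compound 2 and a 1.6-fold higher number (0.22 log units; within the scatter) from compound 3 to compound 4, 2.9-fold (0.46 log units) apart, beyond the scatter of two such steps. The same four compounds read the other way give a 3.7-fold higher number from compound 2 to compound 4 (0.57 log units; beyond the scatter), and pyridin-4-yl in place of pyridin-3-yl likewise depends on the core that receives it: the same change on two cores in this assay, a 1.3-fold higher number (0.11 log units; within the scatter) from compound 1 to compound 3 and a 3.7-fold higher number (0.57 log units; beyond the scatter) from compound 2 to compound 4, 2.9-fold (0.46 log units) apart, beyond the scatter of two such steps. This shows that neither change could be transferred as a fixed step among these four compounds, but it does not show why, and a single square of compounds supports no rule for the wider series.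

The compounds shown leave open how a bromo or methyl group in the same place on the sulfonyl-bound aromatic ring would behave on either core. They also leave open whether a pyridin-2-yl group would follow compound 2 or compound 4 in its response to that exchange.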